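Swapping the side chain on compound 3

The source may hold more compounds than are shown below. What is called first, only, known or untested is meant among the compounds shown, and "the series" means these compounds.

In an ADME assay on microsomes from liver (Mus musculus, strain CD-1) for metabolic stability, read by LC-MS, tested at 2 uM (on this read-out higher numbers stand for a longer-lived compound and lower numbers for a shorter-lived compound), compound 1 `CC(=O)N1CCC(NC(=O)c2ccncc2Nc2cc(-c3ccc4ccn(C)c4c3)c3nccnc3c2)CC1` gives 0.117 h. Compound 2 `CN1CC(NC(=O)c2ccncc2Nc2cc(-c3ccc4ccn(C)c4c3)c3nccnc3c2)C1` gives > 1 h, which is a limit and not a number. Compound 3 `CC(=O)N1CC(CNC(=O)c2ccncc2Nc2cc(-c3ccc4ccn(C)c4c3)c3nccnc3c2)C1` gives > 1 h, also a limit and not a number. Compound 3 therefore stands at the limit of > 1 h in this assay, at which 2 of the 3 values shown sit, and its true half-life remains unread.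

Compound 4 `CC(=O)N1CCC(NC(=O)c2ccncc2Nc2cc(-c3ccc4ccn(C)c4c3)c3nccnc3c2)C1` carries 1-acetylpyrrolidin-3-yl in place of (1-acetylazetidin-3-yl)methyl on an amide-type nitrogen.

The closest guide is an at least 8.5-fold higher number from compound 1 to compound 3 (0.93 log units; beyond the scatter), where the 1-acetylpiperidin-4-yl group gives way to the group now being replaced. A similar size appears in an at least 8.5-fold higher number from compound 1 to compound 2 (0.93 log units; beyond the scatter), while a step that the two limits leave unreadable from compound 2 to compound 3 tells nothing. The 1-acetylpyrrolidin-3-yl group resembles the 1-acetylpiperidin-4-yl group of compound 1, which gives 0.117 h, so part of that gain is expected to be lost. The step expected is an at least 2.2-fold lower number from compound 3 to compound 4 (0.34 log units; beyond the scatter), toward a shorter half-life. For compound 4 the estimated half-life is 0.45 h, with an expected range from 0.15 h to 1.2 h.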

Compound 4, half-life: 0.667 h
Compound 4: the middle estimate sits 1.5-fold (0.17 log units) below what was measured, and the stated range covers the measured number.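

In this assay, the 1-acetylpyrrolidin-3-yl group on the amide-type nitrogen gives a 5.7-fold higher number from compound 1 to compound 4 (0.76 log units; beyond the scatter), so the clear gain over compound 1 does not depend on a four-membered ring or a methyl link. The steps to the azetidine compounds are only floors, an at least 1.4-fold lower number from compound 3 to compound 4 (0.17 log units; that floor lies within the scatter) and an at least 1.4-fold lower number from compound 2 to compound 4 (0.17 log units; that floor lies within the scatter), so neither establishes a real loss when the same atoms of compound 3 are joined differently. Compounds 2 and 3 each carry a limit and not a number: the limit of > 1 h in this assay, at which 2 of the 4 values shown sit.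

The true size of the gap from either of those compounds to compound 4 therefore stays unread. Also open, from the compounds shown here alone, is whether a free amine in place of the acetyl group of compound 4 would keep this half-life.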